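This account rests on a few compounds, and the source may have more. Where it says the series, first, only, none or still open, it means among the compounds named here.

Measured so far in a functional assay on A549 cells (Homo sapiens) for antiproliferative activity, read by MTT assay, with a stated time of 96 h; on this read-out higher numbers stand for weaker inhibition and lower numbers for stronger inhibition:
Compound 1 `COC(=O)/C=C1/SC(N2N=C(c3cc4ccccc4o3)CC2c2ccc(F)cc2)=NC1=O` gives 0.808 ug/mL in this assay.
Compound 2 `COC(=O)/C=C1/SC(N2N=C(c3cc4ccccc4o3)CC2c2ccc(Cl)cc2)=NC1=O` gives 1.08 ug/mL in this assay.

Of the two numbers, compound 2 holds the higher one, but a 1.3-fold higher number from compound 1 to compound 2 (0.13 log units; within the scatter), so the two compounds cannot be separated on this evidence. The next compound, compound 3 `COC(=O)/C=C1/SC(N2N=C(c3cc4ccccc4o3)CC2c2cccc(Br)c2)=NC1=O`, differs from compound 2 by one change: 3-bromophenyl in place of 4-chlorophenyl on a saturated ring carbon. For the measured compounds named here, the only measured step, from compound 1 to compound 2, swaps one halogen for another at the same spot on the phenyl ring and produces no real movement. Going by the values given here, the change to compound 3 both swaps the halogen and moves it to another spot on the phenyl ring, which no measured step covers directly. With a halogen swap having shown no movement, the step to compound 3 is expected to be a 1.1-fold higher number from compound 2 to compound 3 (0.05 log units; within the scatter), that is, nothing beyond the scatter, with added uncertainty from the new position. Compound 3 is therefore expected to give about 1.2 ug/mL in this assay, most likely between 0.45 ug/mL and 3.2 ug/mL.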

Compound 3, half-maximal inhibitory concentration: 4.29 ug/mL
For compound 3 the middle estimate is 3.6-fold (0.55 log units) below the measured one, outside the stated range (above it).
By their numbers in this assay, from the lowest: compounds 1 and 2 (each within the scatter of the next); then compound 3.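

In this assay, the group on this saturated ring carbon clearly affects the read-out: a 4.0-fold higher number from compound 2 to compound 3 (0.60 log units; beyond the scatter), and a 5.3-fold higher number from compound 1 to compound 3 (0.73 log units; beyond the scatter). Both steps point to weaker inhibition with 3-bromophenyl, whereas 4-fluorophenyl and 4-chlorophenyl could not be told apart, so this position does not accept every halogen-bearing phenyl group equally. No measurement shown here gives a reason for the shift.

Since the halogen and its place on the phenyl ring change together, the compounds shown cannot say which of the two changes accounts for the step; 4-bromophenyl and 3-chlorophenyl would pull them apart. They also leave open how this position responds to a phenyl group carrying no halogen, such as plain phenyl, 4-methoxyphenyl or 4-aminophenyl.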